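Replacing the pyridin-3-yl group of compound 3

The compounds below may be only part of what the source reports. "The series", "measured", "known", "first", "only" and "open" are said of these compounds alone.

Three related compounds have entries so far in an ADME assay on J774 cells (Mus musculus) for antiproliferative activity, with a stated time of 72 h; on this read-out higher numbers stand for an effect only at larger amounts of compound and lower numbers for an effect already at smaller amounts. For compound 1 (`CCc1c(C)[nH]c2cc(OCCCOC(=O)C(CC)C(C)=O)c(Cl)cc2c1=O`) the entry reads "not determined" (no result reported) and offers no number to compare. Compound 2 (`CCc1c(C)[nH]c2cc(OCCOc3ccccc3)ccc2c1=O`) shows 4000 nM as its result, while compound 3 (`CCCCc1cc2c(=O)c(-c3cccnc3)c(C)[nH]c2cc1OCCOc1ccccc1`) shows 23000 nM as the higher of the two numbers. Compound 3 therefore needs a larger amount for an effect, and its gap to compound 2 lies beyond the usual scatter. These two compounds differ in more than one place, so the gap cannot be tied to a single change.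

Compound 4 (`CCCCc1cc2c(=O)c(-c3ccc(C(F)(F)F)cc3F)c(C)[nH]c2cc1OCCOc1ccccc1`) has not yet been measured. It carries 2-fluoro-4-(trifluoromethyl)phenyl in place of pyridin-3-yl on an aromatic carbon, and the rest of compound 3 stays the same.

Within the data shown here, no measured pair differs in just one place, so nothing shows directly what such a swap does. Among the measured compounds shown here, the only pointer is that compound 3 at 23000 nM stands above compound 2 at 4000 nM on the scale, so a lower number in this assay seems likelier than a higher one. We estimate a 2.3-fold lower number from compound 3 to compound 4 (0.36 log units; beyond the scatter) as a modest move, only slightly beyond the scatter. For compound 4 the estimate is 10000 nM with an expected range from 2500 nM to 40000 nM as the likely span.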

Compound 4, half-maximal effective concentration: 19000 nM
Compound 4: middle estimate off by 1.9-fold (0.28 log units), on the low side, within the range that was stated.
By their numbers in this assay, from the lowest: compound 2; then compounds 4 and 3 (each within the scatter of the next).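

In this assay, among these compounds, the swap of pyridin-3-yl for 2-fluoro-4-(trifluoromethyl)phenyl on the aromatic carbon gives the first comparison that changes only one place, a 1.2-fold lower number from compound 3 to compound 4 (0.08 log units; within the scatter), so on this read-out the two compounds cannot be told apart. The earlier compounds shown here could not show that this position accepts a carbon-only aromatic ring of 11 heavy atoms in place of a nitrogen-containing aromatic ring of 6 heavy atoms with no difference beyond the usual scatter; losing the ring nitrogen and adding the fluorine and trifluoromethyl groups together leaves the read-out where it was. No measurement of any property of these compounds bears on why this result came out as it did.

As far as these compounds go, both groups tested here are six-membered aromatic rings, so it remains open whether something of a different kind at this carbon, such as a carboxylic acid, a simple amine or a short alkyl chain, would shift the number beyond the scatter. Compound 2, at 4000 nM, differs from both of these compounds in more than one place, so which of those differences separates it from them also remains unresolved.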